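The source may hold more compounds than are shown below. What is called first, only, known or untested is meant among the compounds shown, and "the series" means these compounds.

Measured so far:

Compound 1 `Cc1ncnc2c1ccn2[C@@H]1C=C(CO)[C@@H](O)[C@H]1O` was tested in an ADME assay on Huh-7 cells (Homo sapiens) for cytotoxicity (on this read-out lower numbers stand for higher toxicity in this test and higher numbers for lower toxicity in this test), and gave > 100000 nM, which is a limit of the assay and not a number.

Compound 2 `Cc1ncnc2c1c(F)cn2[C@@H]1C=C(CO)[C@@H](O)[C@H]1O` gave > 100000 nM in this assay, again a limit of the assay and not a number.

Compound 1 therefore stands only at a limit on the numbers shown, and the one further value shown is also a limit. The step from compound 1 to compound 2 is a step that the two limits leave unreadable from compound 1 to compound 2. Both values sit at the limit of > 100000 nM in this assay, at which 2 of the 2 values shown sit, so no size can be read from this pair.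

Compound 3 `C#Cc1cn([C@@H]2C=C(CO)[C@@H](O)[C@H]2O)c2ncnc(C)c12` is not yet measured. It differs from compound 1 by ethynyl in place of hydrogen on an aromatic carbon. Going by the values given here, the only measured step, the one from compound 1 to compound 2, changes the same ring position and gives no readable size, so the expectation for compound 3 rests on the fact that both measured compounds stay at the limit of this assay. No step beyond the scatter is expected in either direction. Compound 3 is therefore estimated at 100000 nM, with a range from 30000 nM to 300000 nM, which means an expected step of a number no higher from compound 1 to compound 3 (the limit leaves the size open) from compound 1 to compound 3, most likely reported again as a limit.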

Compound 3, half-maximal cytotoxic concentration: > 100000 nM
Compound 3 was reported as a limit; the forecaster's own chance of this, stated with the estimate: 70%; the middle value sits exactly at the limit.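

In this assay compound 3 gives > 100000 nM as a limit of the assay and not a number. Going by these compounds alone, no step among compound 1, compound 2 and compound 3 can be read, as all three stand together: the limit of > 100000 nM in this assay, at which 3 of the 3 values shown sit. The compounds shown leave open how far apart these three actually lie on this read-out.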